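Hydroxy to methoxy on compound 1: expected outcome

The source may hold more compounds than are shown below. What is called first, only, known or untested is meant among the compounds shown, and "the series" means these compounds.

Compound 1 `Cc1nc2ccc(Br)cc2c(=O)n1NCc1nnc(N2C(=O)CSC2c2ccc(O)cc2)s1` gives 60% in a functional assay on the whole organism (strain albino) with Rattus norvegicus as the target, in the maximal electroshock model, with a stated time of 1 h, at a dose of 30 mg/kg by the intraperitoneal route; a lower number here means less inhibition, a higher number more inhibition at the dose given (going by the name of the read-out). Compound 2 `Cc1nc2ccccc2c(=O)n1NCc1nnc(N2C(=O)CSC2c2ccc(O)cc2)s1` gives 60% and compound 3 `Cc1nc2ccccc2c(=O)n1NCc1nnc(/N=C/c2ccc(O)cc2)s1` gives 50% in the same assay; compound 1 is level with compound 2 and within the scatter of compound 3, so no order among the three is claimed. Among the measured compounds shown here, the only single-site step measured, no change at the digits printed from compound 1 to compound 2 (within the scatter), exchanges bromo for hydrogen on an aromatic carbon and stays within the scatter. Compound 4 `COc1ccc(C2SCC(=O)N2c2nnc(CNn3c(C)nc4ccc(Br)cc4c3=O)s2)cc1` differs from compound 1 by methyl in place of hydrogen on an oxygen on an aromatic ring, read one bond further out as hydroxy to methoxy. For the measured compounds named here, no measured pair touches this oxygen, so the expectation rests on the flat behaviour seen so far. The step of no change at the digits printed from compound 1 to compound 4 (within the scatter) is therefore expected to stay within the scatter. Compound 4 is estimated at 60%, with a range from 40% to 75%.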

Compound 4, a percentage reported as inhibition, in the whole organism at one dose (the size of the read-out at that dose, not a potency): 60%
For compound 4 middle estimate and measured number coincide at the digits printed; measured number inside the range.
By their numbers in this assay, from the lowest: compounds 3, 1, 2 and 4 (each within the scatter of the next).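

At the oxygen on an aromatic ring, capping with methyl reads (no change at the digits printed from compound 1 to compound 4 (within the scatter)) in this assay. The free hydroxy hydrogen is therefore not needed to hold this one-dose read-out on the core of compound 1, and the position accepts hydroxy to methoxy within the scatter. No available measurement offers an explanation for this result.

Still open, as far as these compounds go, is whether a longer chain on this oxygen, such as ethoxy or benzyloxy, stays within the scatter. From the compounds shown here alone, an amine or a carboxylic acid in place of hydroxy also remains open.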